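The source may hold more compounds than are shown below. What is called first, only, known or untested is meant among the compounds shown, and "the series" means these compounds.

Working notes on the series. Compound 3 `Cc1c(N(C)C)nc(CCCCCCCCCCO)c(O)c1C` stands lowest of the three measured compounds in a functional assay on cells (Lymphocyte, Homo sapiens), read by trypan blue exclusion, with a stated time of 16 h, tested at 0.5 uM; on this read-out lower numbers stand for a weaker effect and higher numbers for a stronger effect at the one concentration tested: compound 3 gives 28%, while compound 1 `CCCCCCCCCCCCCCCCc1c(C)c(N(C)C)nc(C)c1O` gives 75% and compound 2 `CCCCCCCCCCc1c(C)c(N(C)C)nc(C)c1O` gives 84%. Going by the values given here, the one step measured within the set, a number 9 percentage points higher from compound 1 to compound 2 (within the scatter), concerns chain length only and does not touch the change at hand.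

Compound 4 `CCCCCCCCCCc1nc(N(C)C)c(C)c(C)c1O` differs from compound 3 by hydrogen in place of hydroxy on a saturated chain carbon, ten or more bonds along the chain from an aromatic carbon. Among the compounds with values here, no measured pair bears directly on this change; what the numbers show is that the two compounds carrying an unsubstituted chain, compound 1 and compound 2, sit far above compound 3. On that basis a rise beyond the scatter is expected for compound 4, estimated at a number 42 percentage points higher from compound 3 to compound 4 (beyond the scatter), giving an expected value of 70% with a range from 40% to 90%.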

Compound 4, a percentage reported as activity, at one concentration (the size of the read-out at that concentration, not a potency): 74%
Beside the measured number, compound 4's estimate is 4 percentage points below it; measured number inside the range.
By their numbers in this assay, from the lowest: compound 3; then compounds 4, 1 and 2 (each within the scatter of the next).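

In this assay, going by these compounds alone, this is the first direct pair for the change at this place on the chain, and hydrogen in place of hydroxy gives a number 46 percentage points higher from compound 3 to compound 4 (beyond the scatter). The earlier step concerned chain length only and stayed within the scatter, whereas this single change on a saturated chain carbon moves the read-out by a large amount. No available data explain the size of this step. As far as these compounds go, whether an amine or a carboxylic acid at the same place reads like hydroxy or like hydrogen remains open, as does whether a longer chain carrying hydroxy shows the same gap.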